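The source may hold more compounds than are shown below. What is called first, only, known or untested is meant among the compounds shown, and "the series" means these compounds.

Compound 1 `O=C(CCCCC1CCSS1)NCc1cn(CCCOc2ccc3cc(C(=O)O)c(=O)oc3c2)nn1`: 73.5%
Compound 2 `O=C(CCCCC1CCSS1)NCc1cn(CCCOc2ccc3cc(-c4ccc(Cl)c(Cl)c4)c(=O)oc3c2)nn1`: 54.8%
Compound 3 `O=C(CCCCC1CCSS1)NCc1cn(CCCCOc2ccc3cc(-c4ccccc4)c(=O)oc3c2)nn1`: 20.5%

In a functional assay on PC-12 cells (Rattus norvegicus) for cytotoxicity, read by MTT assay, with stated times of 3 h and 2 h, tested at 50 uM (on this read-out lower numbers stand for a weaker effect and higher numbers for a stronger effect at the one concentration tested), compound 3 stands lowest of the three numbers, beyond the scatter of both others; compound 2 is nearest to it and compound 1 furthest. Compound 4 `O=C(CCCCC1CCSS1)NCc1cn(CCCCOc2ccc3cc(-c4ccc(Cl)c(Cl)c4)c(=O)oc3c2)nn1` has not yet been measured. It differs from compound 3 in one place: 3,4-dichlorophenyl in place of phenyl on an aromatic carbon. Within the data shown here, only one measured step touches the same spot, a number 18.7 percentage points lower from compound 1 to compound 2 (beyond the scatter), where a carboxy group was exchanged for the same 3,4-dichlorophenyl group and the number fell modestly. Among the measured compounds shown here, no pair of measured compounds shows phenyl against 3,4-dichlorophenyl directly; compound 2 and compound 3 differ both in this group and in the length of the chain, so their values alone cannot be split into two steps. With the nearest comparison pointing downward, but starting from an already low number for compound 3, the change is expected to be small, a number 0.5 percentage points lower from compound 3 to compound 4 (within the scatter), and not beyond the scatter. Compound 4 is therefore estimated at 20% in this assay, with a range from 8% to 40%.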

Compound 4, a percentage reported as activity, at one concentration (the size of the read-out at that concentration, not a potency): 69.5%
Estimate against measurement, compound 4: 49.5 percentage points below, and the stated range ends below it.
By their numbers in this assay, from the lowest: compound 3; then compound 2; then compounds 4 and 1 (each within the scatter of the next).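

In this assay, the only thing that enters on this aromatic carbon is a pair of chlorine atoms on the phenyl group, and that gives a number 49 percentage points higher from compound 3 to compound 4 (beyond the scatter) on the same core and chain. Both groups are one six-membered aromatic ring of carbon only, so the result shows that the read-out at this position depends on what that ring carries and not merely on a ring being present. Among these compounds, the one earlier step at this carbon, a number 18.7 percentage points lower from compound 1 to compound 2 (beyond the scatter), went the other way with the same 3,4-dichlorophenyl group entering, so that group's effect on the number depends on what it replaces, although these two steps sit on different chains. Nothing measured here gives a reason for the size of this rise.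

Still open, from the compounds shown here alone, is whether both chlorine atoms are needed, which a phenyl group carrying a single chlorine would test, and whether fluorine or methoxy on the phenyl ring would act in the same way. Also open, going by these compounds, is how a carboxylic acid at this carbon would read on the chain of compound 3, and how the numbers would run at concentrations other than the single one tested.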